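A few compounds are considered here, and "the series" means these few. Any claim that something is new, unique, unknown or untested is made for them only; others in the source may bear on it.

In a functional assay on COLO 205 cells (Homo sapiens) for inhibition, read by sulforhodamine B assay, with a stated time of 48 h, tested at 50 uM (a higher number here means more inhibition of growth at the concentration tested, a lower number less inhibition of growth), compound 1 `COc1cc(/C=C/C(=O)/C=C/c2cccc3ccccc23)ccc1OCc1cn(CCOc2cc(=O)oc3ccccc23)nn1` gives 85%, the highest of the three measured numbers and beyond the scatter of the other two. Compound 2 `COc1ccccc1/C=C/C(=O)/C=C/c1ccc(OCc2cn(CCCOc3cc(=O)oc4ccccc34)nn2)c(OC)c1` gives 57% and compound 3 `COc1cc(/C=C/C(=O)/C=C/c2ccco2)ccc1OCc1cn(CCCCOc2cc(=O)oc3ccccc23)nn1` gives 43%. Neither of these carries naphthalen-1-yl, but they differ from compound 1 in more than one place, so no single change has yet been measured. Compound 4 `COc1ccc(/C=C/C(=O)/C=C/c2ccc(OCc3cn(CCOc4cc(=O)oc5ccccc45)nn3)c(OC)c2)cc1` differs from compound 1 in one place: 4-methoxyphenyl in place of naphthalen-1-yl on a double-bonded chain carbon bound to a double-bonded chain carbon. The group change is 4-methoxyphenyl in place of naphthalen-1-yl on a double-bonded chain carbon bound to a double-bonded chain carbon. Expected in this assay is a fall beyond the scatter, estimated as a number 20 percentage points lower from compound 1 to compound 4 (beyond the scatter). For compound 4 the estimated value is 65%, with an expected range of 45% to 82%.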

Compound 4, percent growth inhibition at one concentration: 68%
The estimate for compound 4 lay 3 percentage points below the measured number; measured number inside the range.
By their numbers in this assay, from the lowest: compound 3; then compound 2; then compound 4; then compound 1.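

In this assay, going by these compounds alone, 4-methoxyphenyl in place of naphthalen-1-yl on a double-bonded chain carbon bound to a double-bonded chain carbon gives the first single-change reading, a number 17 percentage points lower from compound 1 to compound 4 (beyond the scatter), a modest fall beyond the scatter. Naphthalen-1-yl is therefore not required at this position for substantial inhibition of growth, since compound 4 still gives 68% at the concentration tested. No measurement on hand accounts for the fall.

From the compounds shown here alone, whether the loss tracks the missing second ring or the entering methoxy remains open, as a plain phenyl or a 4-aminophenyl at this position would be needed to separate them. The effect of the chain to the triazole-linked end also remains unread, as compound 2 and compound 3 differ from the others in more than one place.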